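Maleimide chalcone series: carboxy in place of methoxy

The compounds below may be only part of what the source reports. "The series", "measured", "known", "first", "only" and "open" are said of these compounds alone.

Among the compounds with values here, compound 2 `COc1ccc(/C=C/C(=O)c2ccc(N3C(=O)C=CC3=O)cc2)cc1` gives 7900 nM in a functional assay on MOLT-4 cells (Homo sapiens) for cytotoxicity (a higher number here means a weaker inhibitor, a lower number a stronger inhibitor), the lower of the two numbers measured so far. Compound 1 `O=C(/C=C/c1ccccc1)c1ccc(N2C(=O)C=CC2=O)cc1` gives 9500 nM in this assay. Within the data shown here, the one step measured, a 1.2-fold lower number from compound 1 to compound 2 (0.08 log units; within the scatter), shows that adding methoxy to the ring on the far side of the enone left the number essentially unchanged.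

Compound 3 `O=C(O)c1ccc(/C=C/C(=O)c2ccc(N3C(=O)C=CC3=O)cc2)cc1` has not been measured. It differs from compound 2 by carboxy in place of methoxy on an aromatic carbon, para to a large group. Among the measured compounds shown here, no measured step involves carboxy, so only the hydrogen-to-methoxy step offers any guide, and that step was within the scatter. Anything beyond the scatter in this assay is therefore not expected with confidence, though the wider range allows for a somewhat higher number. Compound 3 is estimated at 12000 nM, between 4000 nM and 40000 nM, an expected step of a 1.5-fold higher number from compound 2 to compound 3 (0.18 log units; within the scatter).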

Compound 3, half-maximal inhibitory concentration: 178000 nM
Estimate against measurement, compound 3: 15-fold (1.17 log units) below, and the stated range ends below it.
By their numbers in this assay, from the lowest: compounds 2 and 1 (each within the scatter of the next); then compound 3.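

In this assay the position on an aromatic carbon, para to a large group, proves far from indifferent to what it carries: carboxy in place of methoxy gives a 23-fold higher number from compound 2 to compound 3 (1.35 log units; beyond the scatter) and carboxy in place of hydrogen gives a 19-fold higher number from compound 1 to compound 3 (1.27 log units; beyond the scatter) on the same carbon. Compound 1 and compound 2 alone showed only that hydrogen and methoxy stand within the scatter of each other, whereas the two new steps agree in size and both point to the entering carboxy, with its hydrogen-bond donor, as the change that matters. Nothing at hand bears on the cause of this loss.

Open, from the compounds shown here alone, is whether the loss belongs to the carboxylic acid as such or would also follow a methyl ester, a primary amide or an amine on this carbon. Also open, going by these compounds, is whether carboxy at another place on this ring would give a step of similar size.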